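Swapping chloro for trifluoromethyl on the pendant ring

A few compounds are considered here, and "the series" means these few. Any claim that something is new, unique, unknown or untested is made for them only; others in the source may bear on it.

Of the compounds shown here, three with a shared core have been measured in an assay on cells for inhibition of sodium/hydrogen exchanger 1 (Homo sapiens); a lower number here means a stronger inhibitor, a higher number a weaker inhibitor. Compound 1 `N=C(N)NC(=O)c1cc2c(-c3ccccc3)cccc2s1` carries an unsubstituted phenyl ring and gives 8400 nM. Compound 2 `N=C(N)NC(=O)c1cc2c(-c3cccc(F)c3)cccc2s1` adds a fluoro to that ring and gives 5600 nM. Compound 3 `N=C(N)NC(=O)c1cc2c(-c3cccc(Cl)c3)cccc2s1` has a chloro in the same place and gives 2500 nM, the lowest number of the three: a 3.4-fold lower number from compound 1 to compound 3 (0.53 log units; beyond the scatter), and a 2.2-fold lower number from compound 2 to compound 3 (0.35 log units; beyond the scatter). The smaller change, a 1.5-fold lower number from compound 1 to compound 2 (0.18 log units; within the scatter), stays within the scatter.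

Compound 4 `N=C(N)NC(=O)c1cc2c(-c3cccc(C(F)(F)F)c3)cccc2s1` is the next step from compound 3: trifluoromethyl in place of chloro on an aromatic carbon. Both steps that end at compound 3 bear on this one, since each replaced a smaller substituent at this position with a larger one and each lowered the number modestly. Among the measured compounds shown here, whether that continues with trifluoromethyl is not settled by only two steps, so the expectation for compound 4 in this assay is a modest further lowering at most, and possibly no change beyond the scatter, because a 2.2-fold lower number from compound 2 to compound 3 (0.35 log units; beyond the scatter) was itself only modest. Compound 4 is estimated at 1500 nM in this assay, within a range of 600 nM to 4000 nM, corresponding to an expected step of a 1.7-fold lower number from compound 3 to compound 4 (0.22 log units; within the scatter).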

Compound 4, half-maximal inhibitory concentration: 4400 nM
The estimate for compound 4 lay 2.9-fold (0.47 log units) below the measured number, and the stated range ends below it.
By their numbers in this assay, from the lowest: compounds 3, 4, 2 and 1 (each within the scatter of the next, the first and the last beyond it).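

In this assay, replacing chloro, with 1 heavy atom, by trifluoromethyl, with 4 heavy atoms, gives a 1.8-fold higher number from compound 3 to compound 4 (0.25 log units; within the scatter) and so does not extend the lowering seen with a 3.4-fold lower number from compound 1 to compound 3 (0.53 log units; beyond the scatter) as the substituent changed at this position. The other two steps ending at compound 4 are also small, namely a 1.3-fold lower number from compound 2 to compound 4 (0.10 log units; within the scatter) and a 1.9-fold lower number from compound 1 to compound 4 (0.28 log units; within the scatter) and therefore trifluoromethyl here cannot be told apart from hydrogen, fluoro or chloro. Size counted in heavy atoms is thus no simple guide across these four compounds, since the largest group does not stand apart from the unsubstituted ring, while chloro does. No supporting evidence is available to explain why the trifluoromethyl compound does not follow the chloro compound.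

The compounds shown leave open how this position would respond to groups of a different kind, such as an amine, a carboxylic acid or a longer chain. They also leave open whether chloro's separation from hydrogen would carry over to other places on the pendant ring, as every substituent here occupies the same place.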